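Permeability of a quinoline-free step: compound 3 to compound 4

A few compounds are considered here, and "the series" means these few. Any claim that something is new, unique, unknown or untested is made for them only; others in the source may bear on it.

The measured compounds and their values in an ADME assay for permeability, using PAMPA, with a stated time of 30 min, at pH 7.4; a higher number here means that the compound crosses the layer faster, a lower number that the compound crosses the layer more slowly:
compound 1 `COc1ccc(F)cc1CNCCCNc1ccnc2cc(Cc3ccc(C#N)cc3)ccc12`: 23 10^-6 cm/s
compound 2 `COc1ccc(F)cc1CNCCCNc1ccnc2cc(C3CCCCC3)ccc12`: 23 10^-6 cm/s
compound 3 `Fc1ccc(-c2ccc3c(NCCCNCc4ccco4)ccnc3c2)cc1`: 237 10^-6 cm/s

Compound 3 stands highest of the three values in this assay; compound 1 and compound 2 each lie lower, a gap beyond the scatter. Compound 3 also differs from those two in the amine side chain, so the data do not tie that gap to any single change.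

Compound 4 `c1coc(CNCCCNc2ccnc3cc(CC4CCCCC4)ccc23)c1` has not been measured. It differs from compound 3 in one place: cyclohexylmethyl in place of 4-fluorophenyl on an aromatic carbon. For the measured compounds named here, the one measured step at the same place on the shared core, no change at the digits printed from compound 1 to compound 2 (within the scatter), also put a saturated six-membered ring where an aromatic group had stood, and it stayed within the scatter. On that basis the step of a 1.2-fold lower number from compound 3 to compound 4 (0.07 log units; within the scatter) is expected to be small, with no change beyond the scatter in either direction. Compound 4 is therefore estimated at 200 10^-6 cm/s, within a range of 80 10^-6 cm/s to 450 10^-6 cm/s.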

Compound 4, apparent permeability: 23 10^-6 cm/s
Estimate against measurement, compound 4: 8.7-fold (0.94 log units) above; the whole stated range lies above it.
By their numbers in this assay, from the lowest: compounds 1, 2 and 4 (each within the scatter of the next); then compound 3.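

In this assay, cyclohexylmethyl in place of 4-fluorophenyl on this aromatic carbon gives a 10-fold lower number from compound 3 to compound 4 (1.01 log units; beyond the scatter), so this position is not indifferent to what it carries. The earlier step at the same place, with cyclohexyl in place of 4-cyanobenzyl, gave no change at the digits printed from compound 1 to compound 2 (within the scatter), and so a non-aromatic ring taking the place of an aromatic group does not carry one fixed outcome across these two pairs. The groups exchanged between compound 3 and compound 4 match in heavy atoms, hydrogen-bond donors, hydrogen-bond acceptors and net charge, so those counts do not separate the two compounds.

Nothing among the data shown offers an explanation for the size of this step. Going by these compounds, what a plain phenyl, a piperidine ring or a carboxylic acid would give on this carbon remains open, as does whether the outcome depends on the amine side chain.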